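The source may hold more compounds than are shown below. What is called first, only, known or untested is meant among the compounds shown, and "the series" means these compounds.

Within the data shown here, compound 1 `Oc1cccc(-c2cc(-c3ccccc3C(F)(F)F)cc(-c3cccc(O)c3)n2)c1` is one of only two compounds measured in a functional assay on T47D cells (Homo sapiens) for inhibition; on this read-out lower numbers stand for stronger inhibition and higher numbers for weaker inhibition. In this assay compound 1 gives 4350 nM. Its companion, compound 2 `Oc1cccc(-c2cc(-c3ccc(C(F)(F)F)cc3)cc(-c3cccc(O)c3)n2)c1`, differs only in where the trifluoromethyl sits on its outer ring, and in this assay compound 2 gives 2330 nM. Among the measured compounds shown here, the single measured step, a 1.9-fold lower number from compound 1 to compound 2 (0.27 log units; within the scatter), therefore tells that moving the trifluoromethyl around the ring leaves the read-out essentially unchanged; the two numbers sit within the usual scatter of each other.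

Compound 3 `Oc1cccc(-c2cc(-c3ccccc3OC(F)(F)F)cc(-c3cccc(O)c3)n2)c1` is the unmeasured partner of compound 1. The change is trifluoromethoxy in place of trifluoromethyl on an aromatic carbon. For the measured compounds named here, no measured step in this assay involves a trifluoromethoxy group, so nothing in the numbers points to a shift in either direction. Going by the values given here, the one step at hand concerns position rather than the kind of group, and it was within the scatter. On that basis a step of about a 1.1-fold lower number from compound 1 to compound 3 (0.04 log units; within the scatter) is expected, that is, none beyond the scatter. For compound 3 the estimate in this assay is 4000 nM, with a range from 1400 nM to 11000 nM.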

Compound 3, half-maximal inhibitory concentration: 7950 nM
Beside the measured number, compound 3's estimate is 2.0-fold (0.30 log units) below it, within the range that was stated.
By their numbers in this assay, from the lowest: compounds 2, 1 and 3 (each within the scatter of the next, the first and the last beyond it).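

Among these compounds, putting trifluoromethoxy in place of trifluoromethyl on this aromatic carbon, ortho to a large group, gives in this assay a 1.8-fold higher number from compound 1 to compound 3 (0.26 log units; within the scatter) and so offers the first look at a change in the kind of group, rather than in where the group sits. The entering group carries an oxygen that the leaving group lacks and counts one hydrogen-bond acceptor where the leaving group counts none, yet on this read-out that difference does not separate the two compounds beyond the usual scatter of repeated measurements. No separate measurement bears on this result, so what lies behind it stays unknown.

The compounds shown hold only these two fluorine-bearing groups at this place, so it remains open whether a quite different group there, such as an amine, a carboxylic acid or a longer alkyl chain, would move the number beyond the scatter. Going by these compounds, it is also open whether the same exchange of trifluoromethyl for trifluoromethoxy would behave alike on the outer ring of compound 2, where the trifluoromethyl sits elsewhere.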